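The source may hold more compounds than are shown below. What is called first, only, known or untested is meant among the compounds shown, and "the series" means these compounds.

In a functional assay on HeLa cells (Homo sapiens) for inhibition, with a stated time of 72 h (a lower number here means that less compound is needed, a higher number that more compound is needed for the effect), the three measured compounds stand as follows:

Compound 1 `COc1cc(CNCc2ccncc2)ccc1OCc1cnc(Cl)c(Cl)c1`: 220 nM
Compound 2 `COc1cc(CNCc2ccncc2)ccc1OCc1ccc(C)cc1`: 5000 nM
Compound 3 `COc1cc(CNCC2CCCO2)ccc1OCc1ccc(Cl)nc1`: 66000 nM

Compound 3 thus has the highest number of the three, with compound 2 the nearest and compound 1 the furthest. Among the compounds with values here, the only single-point comparison available, a 23-fold higher number from compound 1 to compound 2 (1.36 log units; beyond the scatter), concerns the group on the oxygen side of the shared core and therefore does not bear directly on the change considered here.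

Compound 4 `COc1cc(CNCc2cccnc2)ccc1OCc1ccc(Cl)nc1` is compound 3 with one change: pyridin-3-yl in place of oxolan-2-yl on a saturated chain carbon bound to an amine nitrogen. Within the data shown here, compounds 1 and 2, which both carry an aromatic ring at that place, differ from compound 3 in two places, so no single step covers this move; their values only hint that a lower number is plausible.

Compound 4 is estimated at 8000 nM, with a range from 1500 nM to 40000 nM. The expected step is an 8.3-fold lower number from compound 3 to compound 4 (0.92 log units; beyond the scatter), a lower number, though with wide uncertainty.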

Compound 4, half-maximal effective concentration: 5000 nM
Compound 4: middle estimate off by 1.6-fold (0.20 log units), on the high side, and the stated range covers the measured number.
By their numbers in this assay, from the lowest: compound 1; then compounds 2 and 4 (each within the scatter of the next); then compound 3.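

In this assay, putting pyridin-3-yl in place of oxolan-2-yl on a saturated chain carbon bound to an amine nitrogen gives a 13-fold lower number from compound 3 to compound 4 (1.12 log units; beyond the scatter) and so shows directly that this place matters, which the earlier step at the other end of the molecule could not show. The change swaps a five-membered non-aromatic ring for a six-membered aromatic one, and no measured evidence here explains the step. On these data alone, it remains open whether ring size, aromaticity or the ring nitrogen matters most. A phenyl or cyclohexyl group at this place would help separate these.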